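Moving the Ester and Nitrogen on the Outer Pyridine Ring

The compounds below may be only part of what the source reports. "The series", "measured", "known", "first", "only" and "open" are said of these compounds alone.

Within the data shown here, compound 3 `COC(=O)c1ccc(-c2cnc(C(=O)CCc3ccc(-c4ccccc4)cc3)o2)nc1` gives 2.2 nM in an assay for inhibition of Fatty-acid amide hydrolase 1 (Rattus norvegicus) (on this read-out higher numbers stand for weaker inhibition and lower numbers for stronger inhibition), the lowest of the three numbers measured so far. Compound 1 `O=C(CCc1ccc(-c2ccccc2)cc1)c1ncc(-c2ccncc2)o1` gives 2.3 nM in this assay, a value within the scatter of compound 3, so the two cannot be ordered. Compound 2 `COC(=O)c1ccc(-c2cnc(C(O)CCc3ccc(-c4ccccc4)cc3)o2)nc1` carries an alcohol where compound 3 carries a ketone. In this assay compound 2 gives 1100 nM, a number far higher than that of compound 3 and well beyond the scatter.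

The step to compound 4 `COC(=O)c1cc(-c2cnc(C(=O)CCc3ccc(-c4ccccc4)cc3)o2)ccn1` keeps every atom and only rearranges the outer ring: 2-(methoxycarbonyl)pyridin-4-yl in place of 5-(methoxycarbonyl)pyridin-2-yl on an aromatic carbon. Among the measured compounds shown here, the single measured step that bears on this kind of change is a 1.0-fold lower number from compound 1 to compound 3 (0.02 log units; within the scatter), in which one pyridine pattern replaced another without any shift beyond the scatter. On that ground compound 4 is expected to land close to compound 3. The expected step is a 1.4-fold higher number from compound 3 to compound 4 (0.13 log units; within the scatter). The estimate for compound 4 is 3 nM, with a range from 1 nM to 10 nM.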

Compound 4, inhibition constant: 1.5 nM
Compound 4: the middle estimate sits 2.0-fold (0.30 log units) above what was measured; the measured number falls inside the stated range.
By their numbers in this assay, from the lowest: compounds 4, 3 and 1 (each within the scatter of the next); then compound 2.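

In this assay, moving the ester and the ring nitrogen together, with 2-(methoxycarbonyl)pyridin-4-yl in place of 5-(methoxycarbonyl)pyridin-2-yl, gives a 1.5-fold lower number from compound 3 to compound 4 (0.17 log units; within the scatter), so this rearrangement of the outer ring leaves no difference that can be read. The earlier step changed the ester and the pyridine pattern at once, whereas here methoxycarbonyl in place of hydrogen on an aromatic carbon stands alone and gives a 1.5-fold lower number from compound 1 to compound 4 (0.19 log units; within the scatter), so adding the ester to the pyridin-4-yl ring also shifts nothing beyond the scatter. Nothing given here explains why these changes at this position leave the number in place.

Still open, from the compounds shown here alone, is whether a carboxylic acid or a primary amide in place of the methoxycarbonyl group would stay as close to these values. Equally open, going by these compounds, is whether a plain phenyl ring could replace the outer pyridine.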